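Dimethylamino for ethylamino on the carbonyl carbon

The source may hold more compounds than are shown below. What is called first, only, known or untested is meant among the compounds shown, and "the series" means these compounds.

In an ADME assay on Jurkat cells (Homo sapiens) for cytotoxicity, read by MTT assay, with a stated time of 72 h (on this read-out lower numbers stand for stronger inhibition and higher numbers for weaker inhibition), compound 1 `O=C(O)c1cnc(Oc2ccc3c(c2)B(O)OC3)cn1` gives only a limit of > 100000 nM and no number. Compound 2 `COC(=O)c1cnc(Oc2ccc3c(c2)B(O)OC3)cn1` gives 7590 nM while compound 3 `CCNC(=O)c1cnc(Oc2ccc3c(c2)B(O)OC3)cn1` gives 79900 nM as the higher of the two measured numbers. Within the data shown here, compound 4 `CN(C)C(=O)c1cnc(Oc2ccc3c(c2)B(O)OC3)cn1` carries dimethylamino in place of ethylamino on a carbonyl carbon and no measured step makes this exchange. The nearest steps change other groups on that carbon: an 11-fold higher number from compound 2 to compound 3 (1.02 log units; beyond the scatter) is large, whereas an at least 1.2-fold lower number from compound 1 to compound 3 (0.09 log units; that floor lies within the scatter) is a floor within the scatter. With ethylamino and dimethylamino so alike in size, no step beyond the scatter is expected, and the expected step is a 1.3-fold lower number from compound 3 to compound 4 (0.12 log units; within the scatter) in this assay as an estimate. Compound 4 is estimated at 60000 nM with an expected range from 20000 nM to 100000 nM as its ends.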

Compound 4, half-maximal inhibitory concentration: > 100000 nM
Compound 4 gave a limit, no number; the forecaster's own chance of this, stated with the estimate: 25%; at least 1.6-fold (0.22 log units) between middle value and limit.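

In this assay, the exchange of ethylamino for dimethylamino, which removes the amide hydrogen, shows only an at least 1.2-fold higher number from compound 3 to compound 4 (0.09 log units; that floor lies within the scatter), so the two amides cannot be ranked. Against methoxy on the same carbonyl carbon, dimethylamino gives an at least 13-fold higher number from compound 2 to compound 4 (1.11 log units; beyond the scatter), so both amino groups now stand well above compound 2. The step between compound 1 and compound 4 cannot be read: the limit of > 100000 nM in this assay, at which 2 of the 4 values shown sit.

On these data alone, how far compound 4 lies beyond its limit stays open. Also open, as far as these compounds go, is whether ethoxy would keep the lower number of compound 2, and where a cyclic amine such as pyrrolidine on that carbonyl carbon would fall.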